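Compound 3: trifluoromethyl in place of methoxy

A few compounds are considered here, and "the series" means these few. Any claim that something is new, unique, unknown or untested is made for them only; others in the source may bear on it.

Compound 1 `FC(F)(F)c1ccc(Cn2c(Cl)nc3cc(Cl)c(Cl)cc32)cc1`, which carries trifluoromethyl, reads > 100000 nM in a functional assay on KB cells (Homo sapiens) for inhibition (on this read-out higher numbers stand for weaker inhibition and lower numbers for stronger inhibition), and this is a limit of the assay, not a number. Going by the values given here, compound 2 `COc1ccc(Cn2c(Br)nc3cc(Cl)c(Cl)cc32)cc1` gives 55000 nM in this assay, the only actual number so far. Compound 3 `FC(F)(F)c1ccc(Cn2c(Br)nc3cc(Cl)c(Cl)cc32)cc1` has trifluoromethyl in place of methoxy on an aromatic carbon, para to a large group (trifluoromethyl in place of methoxy on an aromatic carbon). No measured step sizes this change. The expected step is a 1.5-fold higher number from compound 2 to compound 3 (0.16 log units; within the scatter), toward weaker inhibition but probably not beyond the scatter. For compound 3 the estimated value is 80000 nM, with an expected range of 30000 nM to 150000 nM.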

Compound 3, half-maximal inhibitory concentration: > 100000 nM
Compound 3 ended at the assay's limit; the forecaster's own chance of this, stated with the estimate: 50%; middle value at least 1.2-fold (0.09 log units) from the limit.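

In this assay, trifluoromethyl in place of methoxy gives an at least 1.8-fold higher number from compound 2 to compound 3 (0.25 log units; that floor lies within the scatter), so only a floor for this change at this aromatic carbon can be read. The bromo in place of chloro step cannot be read, since compound 1 and compound 3 both stand at a limit. Methoxy remains the only group here with an actual number, and the readings crowd at the top of the range: the limit of > 100000 nM in this assay, at which 2 of the 3 values shown sit.

As far as these compounds go, whether an amine or a hydroxyl at this position would give a lower number than compound 2 stays open. From the compounds shown here alone, the true size of the trifluoromethyl step also stays open.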